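Three triazole phenols with low inhibition and a fourth to come

The compounds below may be only part of what the source reports. "The series", "measured", "known", "first", "only" and "open" are said of these compounds alone.

Compound 1 `COc1ccc(-c2cn(-c3ccc(O)c(C(=O)O)c3)nn2)cc1`: 8%
Compound 2 `COC(=O)c1cc(-n2cc(-c3ccc(OC)cc3)nn2)ccc1O`: 6%
Compound 3 `COC(=O)c1cc(-n2cc(-c3cccc(O)c3)nn2)ccc1O`: 6%

All three measured compounds were tested in a functional assay on HCT-116 cells (Homo sapiens) for inhibition, read by MTT assay, with a stated time of 2 days, tested at 10 uM (a lower number here means less inhibition, a higher number more inhibition at the concentration tested (going by the name of the read-out)), and every one of them sits low. Compound 2 and compound 3 share the same value at the digits printed, while compound 1 stands slightly higher, but none of these differences is beyond the usual scatter.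

Compound 4 `O=C(O)c1cc(-n2cc(-c3cccc(O)c3)nn2)ccc1O` is the unmeasured member. It differs from compound 3 by hydrogen in place of methyl on an oxygen next to a carbonyl group. The same change was already made between two measured compounds: compound 1 differs from compound 2 by hydrogen in place of methyl on an oxygen next to a carbonyl group, and in this assay that step was a number 2 percentage points higher from compound 2 to compound 1 (within the scatter). The place of the change is identical word for word in both pairs, so this is the same change on a different core. The two cores differ by 3-hydroxyphenyl in place of 4-methoxyphenyl on an aromatic carbon, a difference that in this assay gave no change at the digits printed from compound 2 to compound 3 (within the scatter).

Because the earlier step was a number 2 percentage points higher from compound 2 to compound 1 (within the scatter), the step from compound 3 to compound 4 is expected to be similar, a number 2 percentage points higher from compound 3 to compound 4 (within the scatter), a change inside the scatter. Compound 4 is therefore estimated at 8% in this assay, with a likely range from 0% to 18%.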

Compound 4, a percentage reported as inhibition, at one concentration (the size of the read-out at that concentration, not a potency): 5%
Compound 4: the middle estimate sits 3 percentage points above what was measured; the range from low to high includes it.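

In this assay, hydrogen in place of methyl on an oxygen next to a carbonyl group, which turns methoxycarbonyl into carboxy, gives a number 1 percentage points lower from compound 3 to compound 4 (within the scatter). Set beside the same change on the other core, this step does not stand apart from the earlier one: the same change on two cores in this assay, a number 2 percentage points higher (within the scatter) from compound 2 to compound 1 and a number 1 percentage points lower (within the scatter) from compound 3 to compound 4, 3 percentage points apart, within the scatter of two such steps. So on both cores shown, the change leaves the read-out within the scatter, which fits with it carrying over from one core to the other as a change too small to read, but it does not show that the change has a real effect of either sign, or that it would behave alike on a core with a larger response.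

The compounds shown leave open whether an amide or a longer ester chain in place of the methoxycarbonyl or carboxy group would give a step beyond the scatter. They also leave open what an amine on the outer phenyl ring would do in this assay.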